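The source may hold more compounds than are shown below. What is called first, only, known or untested is meant among the compounds shown, and "the series" means these compounds.

Compound 1, `COc1ccc2nc(C)cc(NCc3ccc(F)c(F)c3)c2c1`, gives 12000 nM in a functional assay on MCF-10A cells (Homo sapiens) for antiproliferative activity, with a stated time of 48 h; on this read-out lower numbers stand for an effect already at smaller amounts and higher numbers for an effect only at larger amounts of compound.
Compound 2, `COc1ccc2nc(C)cc(NCc3c(F)cccc3F)c2c1`, gives 13600 nM in this assay.
Compound 3, `COc1ccc2nc(C)cc(NCc3ccc(F)c(C(F)(F)F)c3)c2c1`, gives 14300 nM in this assay.

The three measured compounds share a common core and differ only in the substitution of the benzyl ring. Compound 1 and compound 2 are built from the same atoms joined differently; the difference between the two cores is not broken down here. Their values, together with that of compound 3, lie close to one another, and none of the three can be set apart from the others on this read-out.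

One change is seen once among the measured pairs: trifluoromethyl in place of fluoro on an aromatic carbon, which produced a 1.2-fold higher number from compound 1 to compound 3 (0.08 log units; within the scatter). Compound 4, `COc1ccc2nc(C)cc(NCc3c(F)cccc3C(F)(F)F)c2c1`, has not yet been measured. Going by the values given here, it arises from compound 2 through (trifluoromethyl in place of fluoro on an aromatic carbon), the same kind of change as the one from compound 1 to compound 3, though not the same: in compound 3 the entering trifluoromethyl sits ortho to a fluoro group and meta to a large group, whereas in compound 4 it sits ortho to a large group and meta to a fluoro group.

Among the compounds with values here, since the only measured example of this change stayed within the scatter, the expected step for compound 4 in this assay is a 1.1-fold higher number from compound 2 to compound 4 (0.06 log units; within the scatter), which rests on compound 3 having given 14300 nM after the corresponding change from compound 1. Compound 4 is therefore estimated at 15500 nM, with a likely range from 8000 nM to 30000 nM.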

Compound 4, half-maximal effective concentration: 14000 nM
Estimate against measurement, compound 4: 1.1-fold (0.04 log units) above; measured number inside the range.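

In this assay, the replacement of fluoro by trifluoromethyl gave a 1.0-fold higher number from compound 2 to compound 4 (0.01 log units; within the scatter), with the entering group ortho to a large group and meta to a fluoro group. Set beside the earlier example, the two steps do not differ: the same change on two cores in this assay, a 1.2-fold higher number (0.08 log units; within the scatter) from compound 1 to compound 3 and a 1.0-fold higher number (0.01 log units; within the scatter) from compound 2 to compound 4, 1.2-fold (0.06 log units) apart, within the scatter of two such steps. This shows that, in these two cases, the change carried from one core to the other without a step that can be told from the scatter, but it does not show that a real effect of the change was transferred, since neither step rises above that scatter and a pair of flat results gives no size or direction that could be expected to hold elsewhere in the series.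

The compounds shown carry only fluoro and trifluoromethyl on the benzyl ring, which leaves open how an amine, a carboxylic acid or a longer alkyl chain at these places would read in this assay. Going by these compounds, it also remains open whether the same replacement would stay this small on a core whose number lies well away from those seen here.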